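A few compounds are considered here, and "the series" means these few. Any claim that something is new, unique, unknown or untested is made for them only; others in the source may bear on it.

Measured so far in an ADME assay on microsomes from liver (Mus musculus) for metabolic stability, read by LC-MS, using NADPH, with stated times of 15 min and 60 min, tested at 4.6 uM; on this read-out higher numbers stand for a longer-lived compound and lower numbers for a shorter-lived compound:
compound 1, `O=C(NCCCCc1ccccc1)n1c2c(oc1=O)CNCC2`, gives only a limit, < 0.25 h.
compound 2, `CC(C)CNC(=O)n1c(=O)oc2ccc(C3CCN(C)CC3)cc21`, gives 0.667 h.
compound 3, `CN1CCN(c2ccc3c(c2)oc(=O)n3C(=O)NCCCCc2ccccc2)CC1=O`, gives 0.5 h.

Compound 3 stands beside compound 2 among the two real numbers; the gap between them lies within the usual scatter, so neither can be called longer-lived. The reading for compound 1 is a limit, not a number, and is set apart here.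

Compound 4, `CN1CCN(c2ccc3c(c2)oc(=O)n3C(=O)NCCCCc2ccccc2)CC1`, differs from compound 3 in one place: 4-methylpiperazin-1-yl in place of 4-methyl-3-oxopiperazin-1-yl on an aromatic carbon. Among the compounds with values here, no measured pair shows this change, so the direction rests on expectation alone. In this assay the step of a 1.3-fold lower number from compound 3 to compound 4 (0.10 log units; within the scatter) is expected to stay within the scatter. For compound 4 the estimate is 0.4 h, with a range from 0.2 h to 0.9 h.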

Compound 4, half-life: < 0.0834 h
Compound 4: no number, only a limit; the forecaster's own chance of this, stated with the estimate: 25%; at least 4.7-fold (0.68 log units) between middle value and limit.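

Among the compounds shown, only this pair differs in one place, and in this assay the swap of 4-methyl-3-oxopiperazin-1-yl for 4-methylpiperazin-1-yl on an aromatic carbon gives an at least 5.9-fold lower number from compound 3 to compound 4 (0.77 log units; beyond the scatter). Within the data shown here, the position is therefore sensitive to this change, which the earlier compounds could not show. The reading for compound 4 is a limit and not a number, so the full size of the step stays unknown: the limit of < 0.0834 h in this assay, at which 1 of the 4 values shown sits.

From the compounds shown here alone, how a morpholin-4-yl or a 4-acetylpiperazin-1-yl group would read on the same aromatic carbon stays open. Going by these compounds, whether the step would hold on another core also stays open.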